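The source may hold more compounds than are shown below. What is called first, only, known or untested is meant among the compounds shown, and "the series" means these compounds.

Compound 1, `COc1cnc(C[S+]([O-])c2nc3cc(OC(F)F)ccc3[nH]2)cc1OC`, gives 2.1 h in an ADME assay, at pH 5; on this read-out higher numbers stand for a longer-lived compound and lower numbers for a shorter-lived compound.
Compound 2, `COc1ccnc(C[S+]([O-])c2nc3cc(OC(F)F)ccc3[nH]2)c1`, gives 0.8 h in this assay.
Compound 3, `COc1cnc(C[S+]([O-])c2nc3cc(OCC(F)(F)F)ccc3[nH]2)c(C)c1OC`, gives 3.3 h in this assay.

Compound 1 and compound 3 lie within the usual scatter of each other, while compound 2 sits lower than both. Compound 1 and compound 2 differ by one change, (hydrogen in place of methoxy on an aromatic carbon), and that change gave a 2.6-fold lower number from compound 1 to compound 2 (0.42 log units; beyond the scatter).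

Compound 4, `COc1ccnc(C[S+]([O-])c2nc3cc(OCC(F)(F)F)ccc3[nH]2)c1C`, is not yet measured. It arises from compound 3 by hydrogen in place of methoxy on an aromatic carbon. The surroundings of the place are not identical to those in compound 1: in compound 3 the carbon is also meta to a methyl group, so this is the same kind of change rather than the same change. How the core of compound 3 differs from the core of compound 1 is not broken down here.

Within the data shown here, a step of a 2.5-fold lower number from compound 3 to compound 4 (0.40 log units; beyond the scatter) is expected from compound 3 to compound 4 because the one prior example of this kind of change gave a 2.6-fold lower number from compound 1 to compound 2 (0.42 log units; beyond the scatter). Compound 4 is therefore estimated at 1.3 h, likely between 0.7 h and 2.5 h.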

Compound 4, half-life: 0.15 h
Estimate against measurement, compound 4: 8.7-fold (0.94 log units) above; the whole stated range lies above it.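

In this assay, hydrogen in place of methoxy on an aromatic carbon gave a 22-fold lower number from compound 3 to compound 4 (1.34 log units; beyond the scatter), so the number fell on both cores, as it had on the earlier pair. The direction of the step carried over from one core to the other, but its size did not: the same change on two cores in this assay, a 2.6-fold lower number (0.42 log units; beyond the scatter) from compound 1 to compound 2 and a 22-fold lower number (1.34 log units; beyond the scatter) from compound 3 to compound 4, 8.4-fold (0.92 log units) apart, beyond the scatter of two such steps The cores of compound 1 and compound 3 differ in more than one place, so these two pairs do not show which difference sets the size of the step, and they give no rule for predicting it on a further core.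

The compounds shown hold only methoxy or hydrogen at this place, so it remains open how an ethoxy group, a chlorine atom or an amine there would behave on either core. As far as these compounds go, it also remains open whether the methyl group alone goes with the larger step, a question that would need a pair of compounds differing only in that group.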